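A few compounds are considered here, and "the series" means these few. Any claim that something is new, unique, unknown or untested is made for them only; others in the source may bear on it.

Working notes on the sulfonamide series. Compound 1 `CCN(Cc1ccccc1)C(=O)C1CCN(S(=O)(=O)c2ccccc2OC)CC1` has no result in a functional assay on CHO cells for positive allosteric modulation of muscarinic acetylcholine receptor M5 (Homo sapiens), read by calcium flux (a higher number here means a larger maximal response, a lower number a smaller maximal response), where compound 1 is recorded as "not determined" (no result reported). Compound 2 `CCN(Cc1ccccc1)C(=O)C1CCN(S(=O)(=O)c2ccc(C)s2)CC1` gives 64% in this assay. Compound 3 `CCN(Cc1ccccc1)C(=O)C1CCN(S(=O)(=O)c2ccc3cccnc3c2)CC1` gives 66% in this assay. Going by the values given here, the only step between measured compounds is a number 2 percentage points higher from compound 2 to compound 3 (within the scatter), so compound 3 and compound 2 sit within the scatter of each other, and no measured number sets compound 3 apart from the rest of the series. Compound 4 `CCN(Cc1ccccc1)C(=O)C1CCN(S(=O)(=O)c2ccc3occc3c2)CC1` is not yet measured. It differs from compound 3 by 1-benzofuran-5-yl in place of quinolin-7-yl on a sulfonyl sulfur. Among the compounds with values here, the one step that bears on this change is the exchange of one aromatic group for another on the same sulfonyl sulfur, and that step, a number 2 percentage points higher from compound 2 to compound 3 (within the scatter), stayed within the scatter. On that basis no step beyond the scatter is expected in this assay for the exchange of the aromatic group on the sulfonyl sulfur. The expected step is a number 2 percentage points lower from compound 3 to compound 4 (within the scatter). Compound 4 is estimated to give 64% in this assay, with a range from 50% to 78%.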

Compound 4, largest response reached (reported as percent of maximum), in percent of the reference or control that the assay uses: 80%
For compound 4 the middle estimate is 16 percentage points below the measured one; measured number above the stated range.
By their numbers in this assay, from the lowest: compounds 2 and 3 (each within the scatter of the next); then compound 4.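

The exchange of one aromatic group for another on the sulfonyl sulfur is not neutral in this assay: 1-benzofuran-5-yl in place of quinolin-7-yl gives a number 14 percentage points higher from compound 3 to compound 4 (beyond the scatter) and 1-benzofuran-5-yl in place of 5-methylthiophen-2-yl gives a number 16 percentage points higher from compound 2 to compound 4 (beyond the scatter). The earlier exchange, a number 2 percentage points higher from compound 2 to compound 3 (within the scatter), gave no sign of this, so among the three compounds with numbers, compound 4 alone stands apart. Nothing available accounts for the difference between 1-benzofuran-5-yl and the other two groups.

Open, going by these compounds, is whether the higher response belongs to 1-benzofuran-5-yl alone or extends to groups such as indol-5-yl or 1-benzothiophen-5-yl on the same sulfonyl sulfur. Also open, on these data alone, is how a longer chain in place of the ethyl group of the shared core would read in this assay, and compound 1, recorded as "not determined" (no result reported), offers no comparison.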